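Thiazolidinone series: nitro to chloro on the aryl ring

The compounds below may be only part of what the source reports. "The series", "measured", "known", "first", "only" and "open" are said of these compounds alone.

Working notes on two thiazolidinone analogues that carry a piperidine-bearing chain and differ only in the aryl ring. Compound 1 `O=C1CSC(c2ccc([N+](=O)[O-])cc2)N1CCN1CCCCC1` and compound 2 `COc1ccccc1C1SCC(=O)N1CCN1CCCCC1` have been run in an ADME assay on Vero cells (Chlorocebus sabaeus) for cytotoxicity, read by neutral red uptake, tested at 787 ug/mL; a higher number here means a weaker effect of the compound at the concentration tested, a lower number a stronger effect. Compound 1 gives 21% in this assay, and compound 2 gives 30%; the two numbers fall within the scatter of each other, so the change of the aryl substituent between them shows no separation in this assay, and compound 1 cannot be set apart from compound 2 on these figures.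

Compound 3 `O=C1CSC(c2ccc(Cl)cc2)N1CCN1CCCCC1` has not yet been measured in this assay. Against compound 1 the change is chloro in place of nitro on an aromatic carbon. Within the data shown here, no step between measured compounds covers this exchange, so there is no internal reference for its size. With compound 1 at 21% and compound 2 at 30%, the two aryl variants so far sit close together, and the step from compound 1 to compound 3 is expected to stay within the scatter, a number 4 percentage points higher from compound 1 to compound 3 (within the scatter), in no firm direction. Compound 3 is therefore estimated at 25% in this assay, with a range from 10% to 45%.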

Compound 3, a percentage reported as activity, at one concentration (the size of the read-out at that concentration, not a potency): 15%
Compound 3: middle estimate off by 10 percentage points, on the high side, within the range that was stated.
By their numbers in this assay, from the lowest: compounds 3, 1 and 2 (each within the scatter of the next, the first and the last beyond it).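

Among these compounds, the first step that can be read at this position is chloro in place of nitro on an aromatic carbon, para to a large group, and in this assay it comes to a number 6 percentage points lower from compound 1 to compound 3 (within the scatter). Among the compounds shown here, the earlier compounds gave no such single-place comparison, so this is the first direct sign that the read-out at this concentration does not separate these two substituents, even though a group with hydrogen-bond acceptors is replaced by one with none. Nothing available bears on the reason for this result, and one pair cannot support a trend across aryl substituents.

Still open, going by these compounds, is whether other groups at this place, such as an amine, a carboxylic acid or a nitrile, would give a step beyond the scatter in this assay. Also open, on these data alone, is whether the chloro and nitro pair would stay this close on the shared core if the piperidine were replaced by a morpholine or the chain carrying it by a longer chain.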